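Octylsulfonamide benzoic acids: from 4-butylphenyl to phenethyl

This account rests on a few compounds, and the source may have more. Where it says the series, first, only, none or still open, it means among the compounds named here.

Measured compounds:
compound 1, `CCCCCCCCS(=O)(=O)Nc1cc(-c2ccccc2-c2ccccc2)ccc1C(=O)O`, 17100 nM
compound 2, `CCCCCCCCS(=O)(=O)Nc1ccc(-c2ccc(CCCC)cc2)cc1C(=O)O`, 9000 nM
compound 3, `CCCCCCCCS(=O)(=O)Nc1cc(CCc2ccccc2)ccc1C(=O)O`, 37500 nM

All three were tested in an assay on mitochondria (strain BALB/c) for inhibition of glycerol-3-phosphate acyltransferase 1, mitochondrial (Mus musculus), read by scintillation counting, with a stated time of 10 min; a higher number here means a weaker inhibitor, a lower number a stronger inhibitor. Compound 2 gives the lowest of the three numbers, at 9000 nM. Compound 1, with 17100 nM, lies within the scatter of compound 2, so no order between the two can be read. Compound 3, with 37500 nM, stands beyond the scatter above compound 2 and is the only one of the three separated from it.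

The next compound, compound 4, has the structure `CCCCCCCCS(=O)(=O)Nc1ccc(CCc2ccccc2)cc1C(=O)O`. Relative to compound 2 the change is phenethyl in place of 4-butylphenyl on an aromatic carbon. Among the compounds with values here, compound 3 also carries a phenethyl group on the shared core, and it shows the highest number of the three measured, but no step between compound 3 and compound 4 is at hand, so only its value can be noted.

For compound 4 in this assay the expectation is a moderate rise in the number, a step of a 2.2-fold higher number from compound 2 to compound 4 (0.35 log units; beyond the scatter), at the edge of the scatter. Compound 4 is therefore estimated at 20000 nM, within a range of 8000 nM to 50000 nM.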

Compound 4, half-maximal inhibitory concentration: 37500 nM
Estimate against measurement, compound 4: 1.9-fold (0.27 log units) below; the range from low to high includes it.
By their numbers in this assay, from the lowest: compounds 2 and 1 (each within the scatter of the next); then compounds 3 and 4 (each within the scatter of the next).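

In this assay, within the data shown here, the change from 4-butylphenyl to phenethyl on this aromatic carbon, meta to a carboxy group and para to a large group, gives a 4.2-fold higher number from compound 2 to compound 4 (0.62 log units; beyond the scatter), the first sign that the number responds to the group at this position, since the earlier compounds offered no step at all. Both groups hold one six-membered aromatic ring of carbon only and neither has hydrogen-bond donors or acceptors, so among the features counted here they differ only in size, with 10 heavy atoms leaving and 8 entering. Nothing measured here explains the step.

Among these compounds, compound 3 also carries phenethyl on the shared core and has the same printed value as compound 4, with compound 3 at 37500 nM and compound 4 at 37500 nM, but no step between them can be read. Going by these compounds, what a plain phenyl group, a longer chain on the phenyl ring, or a terminal amine or carboxylic acid would do on this carbon remains open, and this single step cannot show whether the change in the number would hold on any other core.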